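Dichlorophenyl for dimethoxyphenyl in a growth inhibition series

The source may hold more compounds than are shown below. What is called first, only, known or untested is meant among the compounds shown, and "the series" means these compounds.

In a functional assay on CAKI-1 cells (Homo sapiens) for inhibition, read by sulforhodamine B assay, with a stated time of 48 h (on this read-out higher numbers stand for weaker inhibition of growth and lower numbers for stronger inhibition of growth), compound 1 `O=C(Cc1csc2nc(-c3ccc(Br)cc3)cn12)N/N=C/c1ccc(O)cc1` gives 49000 nM and compound 2 `COc1cccc(OC)c1/C=N/NC(=O)Cc1csc2nc(-c3ccc(Br)cc3)cn12` gives 33900 nM on the same scale. Among the compounds with values here, these are the only two numbers so far, and they lie within the scatter of each other, so compound 2 cannot be ranked against compound 1. Compound 3 `O=C(Cc1csc2nc(-c3ccc(Br)cc3)cn12)N/N=C/c1ccc(Cl)cc1Cl` has 2,4-dichlorophenyl in place of 2,6-dimethoxyphenyl on a carbon with a double bond to nitrogen. Within the data shown here, one measured step bears on this change, as it altered the group at that same place: a 1.4-fold lower number from compound 1 to compound 2 (0.16 log units; within the scatter) stays within the scatter. Among the measured compounds shown here, no measured compound carries chlorine, so this is thin evidence. The expected step in this assay is a 1.1-fold lower number from compound 2 to compound 3 (0.05 log units; within the scatter) and no move beyond the scatter is expected in either direction. Compound 3 is estimated at 30000 nM (expected range 12000 nM to 70000 nM).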

Compound 3, concentration for total growth inhibition: > 100000 nM
Compound 3 was reported as a limit; the forecaster's own chance of this, stated with the estimate: 10%; middle value at least 3.3-fold (0.52 log units) from the limit.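

In this assay compound 3 is reported only as a limit: the limit of > 100000 nM in this assay, at which 1 of the 3 values shown sits. The position on a carbon with a double bond to nitrogen now proves sensitive to the group it carries: the earlier change there stayed within the scatter, whereas 2,4-dichlorophenyl in place of 2,6-dimethoxyphenyl gives an at least 2.9-fold higher number from compound 2 to compound 3 (0.46 log units; beyond the scatter), a clear loss of growth inhibition. Against 4-hydroxyphenyl the same group gives an at least 2.0-fold higher number from compound 1 to compound 3 (0.30 log units; that floor lies within the scatter), so the gap to compound 1 is not firmly established, and its true size is unknown.

The compounds shown leave open whether this loss follows the chlorine atoms themselves or the pattern in which they sit on the ring. From the compounds shown here alone, whether a plain phenyl or a 4-aminophenyl at this place would fall with compound 3 or with compound 1 also remains open.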